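Thiophen-3-yl in place of a carbamate chain

The source may report more compounds than this note shows. Statements on the series, on what has been measured and on what is new or still open speak of the compounds shown alone.

Three compounds have been measured in an ADME assay on cells (Homo sapiens) for cytotoxicity, read by polymerase chain reaction, with a stated time of 3 days; a lower number here means that less compound is tolerated, a higher number that more compound is tolerated:

compound 1, `CNc1nc(C)c(-c2nc3ccccc3s2)c(N[C@@H]2C[C@H](CO)[C@@H](O)[C@H]2O)n1`: > 25000 nM
compound 2, `COCCNc1nc(C)c(-c2nc3ccccc3s2)c(N[C@@H]2C[C@H](CO)[C@@H](O)[C@H]2O)n1`: 21000 nM
compound 3, `CCOC(=O)NCCNc1nc(C)c(-c2nc3ccccc3s2)c(N[C@@H]2C[C@H](CO)[C@@H](O)[C@H]2O)n1`: 12000 nM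

The value of compound 1 is a limit of this assay, not a number (the limit of > 25000 nM in this assay, at which 1 of the 3 values shown sits). Among the two numbers shown, compound 3 holds the lowest, and its nearest neighbour is compound 2, whose number is within the scatter of it. The steps run as an at least 1.1-fold lower number from compound 1 to compound 2 (0.07 log units; that floor lies within the scatter), an at least 2.0-fold lower number from compound 1 to compound 3 (0.31 log units; beyond the scatter) and a 1.8-fold lower number from compound 2 to compound 3 (0.24 log units; within the scatter).

Compound 4, `Cc1nc(NCc2ccsc2)nc(N[C@@H]2C[C@H](CO)[C@@H](O)[C@H]2O)c1-c1nc2ccccc2s1`, is not yet measured. It differs from compound 3 thus: thiophen-3-yl in place of ((ethoxycarbonyl)amino)methyl on a saturated chain carbon bound to a nitrogen on an aromatic ring. Among the measured compounds shown here, no measured step exchanges a chain substituent for an aromatic ring at this position, so none bears directly on it; the steps seen so far all stay small, and only the step from compound 1 to compound 3 reaches beyond the scatter. Compound 4 is therefore expected to sit near compound 3, with a step of a 1.2-fold lower number from compound 3 to compound 4 (0.08 log units; within the scatter), not clearly beyond the scatter in either direction. The estimate for compound 4 in this assay is 10000 nM, with a range from 4000 nM to 25000 nM.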

Compound 4, half-maximal cytotoxic concentration: 6000 nM
The estimate for compound 4 lay 1.7-fold (0.22 log units) above the measured number; the range from low to high includes it.
By their numbers in this assay, from the lowest: compounds 4, 3 and 2 (each within the scatter of the next, the first and the last beyond it). At a limit, above all of these: compound 1.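

In this assay, among the compounds shown here, this place, on a saturated chain carbon bound to a nitrogen on an aromatic ring, now carries an aromatic ring for the first time, and thiophen-3-yl in place of ((ethoxycarbonyl)amino)methyl gives a 2.0-fold lower number from compound 3 to compound 4 (0.30 log units; within the scatter), so the ring and the carbamate chain cannot be told apart here, whereas thiophen-3-yl in place of methoxymethyl gives a 3.5-fold lower number from compound 2 to compound 4 (0.54 log units; beyond the scatter), a separation from compound 2 that the carbamate chain of compound 3 did not reach. Thiophen-3-yl in place of hydrogen gives an at least 4.1-fold lower number from compound 1 to compound 4 (0.61 log units; beyond the scatter), so a chain is not needed at this place for the number to fall beyond the scatter of the unsubstituted end. Compound 1 stands at a limit of the assay, not at a number, so this step is only a floor: the limit of > 25000 nM in this assay, at which 1 of the 4 values shown sits.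

With a single aromatic ring shown at this place, it remains open whether phenyl, furan-3-yl or thiophen-2-yl would stand with compound 4. From the compounds shown here alone, it also remains open whether a chain ending in an amine or a carboxylic acid would fall nearer to compound 4 or to compound 2.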